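A few compounds are considered here, and "the series" means these few. Any claim that something is new, unique, unknown or untested is made for them only; others in the source may bear on it.

Measured so far:
- compound 2: `COc1cc2c(cc1OC)CN(S(=O)(=O)c1ccc(-n3cc(COc4ccc5ccccc5c4)nn3)cc1)CC2` — > 50 ug/mL
- compound 1: `Cc1ccc(OCc2cn(-c3ccc(S(=O)(=O)N4CCc5ccccc5C4)cc3)nn2)cc1` — > 50 ug/mL

Both numbers are limits of a functional assay on HuCC-A1 cells (Homo sapiens) for cytotoxicity, read by MTT assay, with a stated time of 48 h (on this read-out lower numbers stand for stronger inhibition and higher numbers for weaker inhibition), not measured values. In this assay compound 2 reaches only a limit, > 50 ug/mL. Compound 1 likewise gives only a limit, > 50 ug/mL. So far, then, (the limit of > 50 ug/mL in this assay, at which 2 of the 2 values shown sit). Compound 3 is `COc1cc2c(cc1OC)CN(S(=O)(=O)c1ccc(-n3cc(COc4ccccc4)nn3)cc1)CC2`; it differs from compound 2 by phenyl in place of naphthalen-2-yl on an oxygen on a saturated carbon. Going by the values given here, with no measured step of this kind and only a limit to start from, a shift no larger than the usual scatter is expected, a step that the limit leaves unreadable from compound 2 to compound 3. Compound 3 is therefore estimated at 60 ug/mL, within 25 ug/mL to 150 ug/mL, most likely reported again as a limit.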

Compound 3, half-maximal inhibitory concentration: > 50 ug/mL
Compound 3: no number, only a limit; the forecaster's own chance of this, stated with the estimate: 80%; the middle value is on the limit's open side.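

Compound 2 and compound 3 both give only limits, so replacing naphthalen-2-yl with phenyl produces no step that can be read: the limit of > 50 ug/mL in this assay, at which 3 of the 3 values shown sit.

The compounds shown leave open what any of their actual values is in this assay.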